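The compounds below may be only part of what the source reports. "The series", "measured", "known", "first", "only" and "open" are said of these compounds alone.

Three compounds have been measured in a functional assay on MCF7 cells (Homo sapiens) for cytotoxicity, read by MTT assay, with a stated time of 48 h; on this read-out higher numbers stand for weaker inhibition and lower numbers for stronger inhibition:

compound 1 `C/C(=N\NC(=S)Nc1cccc(I)c1)c1ccccn1`, 45 nM
compound 2 `C/C(=N\NC(=S)Nc1cccc([N+](=O)[O-])c1)c1ccccn1`, 38 nM
compound 3 `C/C(=N/NC(=S)Nc1cccc(F)c1)c1ccccn1`, 9 nM

Compound 3 gives the lowest number of the three; its nearest neighbour is compound 2, and compound 1 lies furthest from it, both beyond the scatter. Among the compounds with values here, the only single-point step among the measured compounds, a 1.2-fold lower number from compound 1 to compound 2 (0.07 log units; within the scatter), swaps one aromatic substituent for another and says nothing about configuration. Compound 4 `C/C(=N\NC(=S)Nc1cccc(F)c1)c1ccccn1` is the case at hand: the two compounds have the same atoms and bonds and differ only in configuration as drawn: 1 of 1 stereo elements differ; a double bond is drawn Z in compound 3 and E in compound 4. Within the data shown here, no measured step bears on such a change, so the expectation rests on compound 3 alone, with a wide range. Compound 4 is estimated at 12 nM (range 4 nM to 40 nM), which means an expected step of a 1.3-fold higher number from compound 3 to compound 4 (0.12 log units; within the scatter).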

Compound 4, half-maximal inhibitory concentration: 9 nM
Compound 4: the middle estimate sits 1.3-fold (0.12 log units) above what was measured, and the stated range covers the measured number.
By their numbers in this assay, from the lowest: compounds 3 and 4 (each within the scatter of the next); then compounds 2 and 1 (each within the scatter of the next).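

In this assay, changing the double bond from Z to E leaves the number where it was (no change at the digits printed from compound 3 to compound 4 (within the scatter)), the first sign that this configuration counts for little with fluoro on the ring, and the comparison is a clean one: the fact that compounds 3 and 4 differ only in the configuration as drawn. With the configuration held as drawn in compound 1 and compound 2, fluoro in place of nitro gives a step beyond the scatter (a 4.2-fold lower number from compound 2 to compound 4 (0.63 log units; beyond the scatter)). Fluoro in place of iodo does likewise (a 5.0-fold lower number from compound 1 to compound 4 (0.70 log units; beyond the scatter)).

On these data alone, whether an amine or a methoxy group in place of fluoro would keep the lower number stays open. So does whether compound 1 and compound 2 would respond in the same way to the same change of configuration.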